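The compounds below may be only part of what the source reports. "The series", "measured", "known", "first", "only" and "open" are said of these compounds alone.

Three members of the series have been run in an ADME assay on HeLa cells (Homo sapiens) for cytotoxicity, read by ATP content, with a stated time of 3 days; on this read-out lower numbers stand for higher toxicity in this test and higher numbers for lower toxicity in this test. Compound 1 `O=c1n(Cc2cc3cnccc3n2CCCCO)c2cnccc2n1C1CC1` returns only a limit, > 100000 nM. Compound 2 `CC(C)CCn1c(Cn2c(=O)n(C3CC3)c3ccncc32)cc2cnccc21` likewise gives a limit in this assay, > 50000 nM. Compound 3 `CS(=O)(=O)CCCn1c(Cn2c(=O)n(C3CNC3)c3ccncc32)cc2cc(Cl)ccc21` also stands at a limit in this assay, > 50000 nM. Every value recorded so far is a limit, sitting at the limit of > 100000 nM in this assay, at which 1 of the 3 values shown sits, or at the limit of > 50000 nM in this assay, at which 2 of the 3 values shown sit. Within the data shown here, the single step between measured compounds that differ in one place, a step that the two limits leave unreadable from compound 1 to compound 2, is left unreadable by the two limits at its ends.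

Compound 4 `CS(=O)(=O)CCCn1c(Cn2c(=O)[nH]c3ccncc32)cc2cc(Cl)ccc21` differs from compound 3 by hydrogen in place of azetidin-3-yl on an aromatic nitrogen. Among the measured compounds shown here, no measured step touches this change, and the only step recorded gives no readable size, so nothing in the data points to a shift in either direction beyond the scatter. The step that the limit leaves unreadable from compound 3 to compound 4 is expected to stay within the scatter. Compound 4 is therefore expected to come out near compound 3, at an estimated 70000 nM with a range of 30000 nM to 200000 nM, most probably again reported only as a limit in this assay.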

Compound 4, half-maximal cytotoxic concentration: > 50000 nM
Compound 4 was reported as a limit (the forecaster's own chance of this, stated with the estimate: 80%); the middle value lies beyond the limit too.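

No new step can be read: compound 3 and compound 4 both stand at limits in this assay, leaving the swap of azetidin-3-yl for hydrogen without a readable size. The compounds shown leave open whether any single change shifts the half-maximal cytotoxic concentration at all.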